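The source may report more compounds than this note shows. Statements on the series, on what has been measured and on what is new or still open speak of the compounds shown alone.

Measured so far in an ADME assay on THP-1 cells (Homo sapiens) for cytotoxicity, read by flow cytometry and propidium iodide staining, with a stated time of 72 h; on this read-out higher numbers stand for weaker inhibition and lower numbers for stronger inhibition:
Compound 1 `Cn1cnc(CS(=O)(=O)c2ccccc2)c1[N+](=O)[O-]`: > 888000 nM (a limit)
Compound 2 `Cn1cnc(CS(=O)(=O)c2ccc(Br)cc2)c1[N+](=O)[O-]`: > 694000 nM (a limit)
Compound 3 `Cc1nc(CS(=O)(=O)c2ccccc2)c([N+](=O)[O-])n1C`: > 846000 nM (a limit)

None of these three entries is a true number. From the compounds shown here alone, compound 3 has only a limit, > 846000 nM, so its real value is unknown. Compound 4 `Cc1nc(CS(=O)(=O)c2ccc(F)cc2)c([N+](=O)[O-])n1C` differs from compound 3 by fluoro in place of hydrogen on an aromatic carbon, para to a large group.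

For the measured compounds named here, two measured steps bear on this change. Bromo in place of hydrogen on an aromatic carbon is a step that the two limits leave unreadable from compound 1 to compound 2. An added methyl group on the shared core is a step that the two limits leave unreadable from compound 1 to compound 3. Neither gives a size to build on, so no change beyond the usual scatter is expected in this assay, and a limit is the likely report again. The expected step is an at least 1.0-fold lower number from compound 3 to compound 4 (0.02 log units; that floor lies within the scatter). The estimate for compound 4 is 800000 nM, with an expected range from 300000 nM to 1000000 nM.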

Compound 4, half-maximal inhibitory concentration: > 797000 nM
Compound 4: a limit, no number; the forecaster's own chance of this, stated with the estimate: 85%; the middle value is on the limit's open side.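

For the compounds shown here, compound 3 and compound 4 each carry only a limit in this assay, and no step between them can be read. The compounds shown leave open every true value and whether any change shifts it.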